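The compounds below may be only part of what the source reports. "The series", "measured", "known", "first", "only" and "open" are said of these compounds alone.

Measured compounds:
compound 1 `Cc1ccc(-c2cc(C(=O)N[C@H]3CCCNC3)c(NC(N)=O)s2)cc1` gives 70 nM in a functional assay on HT-29 cells (Homo sapiens); on this read-out higher numbers stand for an effect only at larger amounts of compound and lower numbers for an effect already at smaller amounts
compound 2 `NC(=O)Nc1sc(-c2ccccc2)cc1C(=O)NCCO` gives "not determined" (no result reported) in this assay

For the measured compounds named here, compound 1 holds the only number in this assay; compound 2 gives nothing to compare against, so no step between measured compounds can be drawn. Compound 3 `NC(=O)Nc1sc(-c2ccc(C(N)=O)cc2)cc1C(=O)N[C@H]1CCCNC1` differs from compound 1 by carbamoyl in place of methyl on an aromatic carbon. Going by the values given here, with no comparable step recorded, the size and direction of this change are open; a shift of moderate size in either direction is plausible, and a result within the scatter cannot be excluded. The estimated step from compound 1 to compound 3 is a 2.1-fold higher number from compound 1 to compound 3 (0.33 log units; beyond the scatter). Compound 3 is expected to give 150 nM, within 40 nM to 600 nM.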

Compound 3, half-maximal effective concentration: 3200 nM
Compound 3: middle estimate off by 21-fold (1.33 log units), on the low side, and the stated range ends below it.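

For the compounds shown here, replacing 4-methylphenyl with 4-carbamoylphenyl gives a 46-fold higher number from compound 1 to compound 3 (1.66 log units; beyond the scatter) in this assay, the first reading at this position. The aromatic carbon para to a large group is therefore sensitive to the substituent it carries, and with the rest of compound 1 unchanged, this single exchange produces a large step. No measured evidence explains the size of the step.

Going by these compounds, it remains open whether the step is specific to carbamoyl or extends to other groups here, such as a nitrile, an amine or a carboxylic acid. A single step also cannot show whether a group larger than methyl is enough to produce such a change.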